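Piperidin-4-yl in place of 3,5-dimethyl-1,2-oxazol-4-yl

The compounds below may be only part of what the source reports. "The series", "measured", "known", "first", "only" and "open" are said of these compounds alone.

Of the compounds shown here, three sharing one core have been measured. In a physicochemical assay for lipophilicity, at pH 7.4 (on this read-out lower numbers stand for lower lipophilicity and higher numbers for higher lipophilicity), compound 1 `CCc1ccc(N(CC(C)C)S(=O)(=O)c2ccc3c(c2)C(=O)CC(C(C)C2CCOCC2)O3)cc1` gives 4.93, compound 2 `CCc1ccc(N(CC(C)C)S(=O)(=O)c2ccc3c(c2)C(=O)CC(C2(C)CCOCC2)O3)cc1` gives 4.71 and compound 3 `CCc1ccc(N(CC(C)C)S(=O)(=O)c2ccc3c(c2)C(=O)CC(c2c(C)noc2C)O3)cc1` gives 4.42. Two measured steps fix the position of compound 3: a number 0.51 log units lower from compound 1 to compound 3 (beyond the scatter), and a number 0.29 log units lower from compound 2 to compound 3 (within the scatter). The remaining measured step runs a number 0.22 log units lower from compound 1 to compound 2 (within the scatter).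

Compound 4 `CCc1ccc(N(CC(C)C)S(=O)(=O)c2ccc3c(c2)C(=O)CC(C2CCNCC2)O3)cc1` has not yet been measured. It carries piperidin-4-yl in place of 3,5-dimethyl-1,2-oxazol-4-yl on a saturated ring carbon.

All three measured steps exchange the group at this same place, and the largest is a number 0.51 log units lower from compound 1 to compound 3 (beyond the scatter). None of them introduces piperidin-4-yl, so they set no firm size for this change. Judging from the structural change itself, a downward shift in this assay, larger than any step seen so far, is expected. The expected step runs a number 1.42 log units lower from compound 3 to compound 4 (beyond the scatter). For compound 4 the estimated value is 3, with an expected range of 2.3 to 3.7.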

Compound 4, distribution coefficient: 2.21
Beside the measured number, compound 4's estimate is 0.79 log units above it, and the stated range ends above it.
By their numbers in this assay, from the lowest: compound 4; then compounds 3, 2 and 1 (each within the scatter of the next, the first and the last beyond it).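

In this assay this position, on a saturated ring carbon next to the ring oxygen, proves far more sensitive than the earlier exchanges suggested: piperidin-4-yl gives a number 2.21 log units lower from compound 3 to compound 4 (beyond the scatter), whereas the largest earlier step was a number 0.51 log units lower from compound 1 to compound 3 (beyond the scatter). The fall holds against each earlier group, with a number 2.50 log units lower from compound 2 to compound 4 (beyond the scatter) and a number 2.72 log units lower from compound 1 to compound 4 (beyond the scatter), so compound 4 stands well apart from the other three. No supporting measurement accounts for the size of this fall.

The compounds shown leave open whether the fall follows the ring nitrogen with its hydrogen or the piperidine ring as a whole. A tertiary amine such as 1-methylpiperidin-4-yl, or a carboxylic acid on the same carbon, would help to separate these readings.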